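The source may report more compounds than this note shows. Statements on the series, on what has been measured and on what is new or still open speak of the compounds shown alone.

Measured compounds:
compound 1, `Nc1scc(CN2CCN(C3CCCCCC3)CC2)c1C(=O)c1ccc(Cl)cc1`, 3.7%
compound 2, `Nc1scc(CN2CCN(c3ccc(F)c(F)c3)CC2)c1C(=O)c1ccc(Cl)cc1`, -78%

Of the compounds shown here, two have been measured in a functional assay on CHO cells with adenosine receptor A1 (Homo sapiens) as the target, read by cAMP accumulation and immunoassay, with a stated time of 6 min, tested at 1 uM; a higher number here means a weaker effect of the compound at the concentration tested, a lower number a stronger effect. Compound 1, `Nc1scc(CN2CCN(C3CCCCCC3)CC2)c1C(=O)c1ccc(Cl)cc1`, gives 3.7% in this assay. Among the measured compounds shown here, compound 2, `Nc1scc(CN2CCN(c3ccc(F)c(F)c3)CC2)c1C(=O)c1ccc(Cl)cc1`, gives -78% in this assay and so stands lowest of the two measured numbers; the nearest measured compound is compound 1, and the only measured step, a number 81.7 percentage points lower from compound 1 to compound 2 (beyond the scatter), lies beyond the scatter and is large.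

Compound 3, `Nc1scc(CN2CCN(c3cc(F)cc(F)c3)CC2)c1C(=O)c1ccc(Cl)cc1`, has not yet been measured. It differs from compound 2 in one place: 3,5-difluorophenyl in place of 3,4-difluorophenyl on an amine nitrogen in a ring. The two compounds contain the same atoms joined differently.

For the measured compounds named here, the one measured step concerns a different change, the exchange of cycloheptyl for 3,4-difluorophenyl, and does not bear directly on the shift of a fluorine within the phenyl ring. Going by the values given here, no measured pair shows what that shift does. The expectation therefore rests on compound 2 alone, and the step is expected to be small, with a slight rise toward weaker effect considered possible. Compound 3 is estimated to give -65% in this assay, within -95% to -25%, which means an expected step of a number 13 percentage points higher from compound 2 to compound 3 (beyond the scatter).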

Compound 3, a percentage reported as activity, at one concentration (the size of the read-out at that concentration, not a potency): -66%
The estimate for compound 3 lay 1 percentage points above the measured number; low and high end bracket the measured number.
By their numbers in this assay, from the lowest: compound 2; then compound 3; then compound 1.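

In this assay, the arrangement of the two fluorines on the phenyl group at the ring amine nitrogen proves to have a measurable effect: 3,5-difluorophenyl in place of 3,4-difluorophenyl gives a number 12 percentage points higher from compound 2 to compound 3 (beyond the scatter), so the effect becomes somewhat weaker with the same atoms joined differently. The large drop seen on leaving cycloheptyl is nevertheless not confined to one fluorine arrangement, as 3,5-difluorophenyl in place of cycloheptyl also gives a number 69.7 percentage points lower from compound 1 to compound 3 (beyond the scatter), and compound 2 and compound 3 both stand far below compound 1 in this read-out. No measurement offered here accounts for the difference between the two fluorine arrangements.

The compounds shown leave open whether the fluorines are needed at all, as a plain phenyl group or a phenyl group carrying a single fluorine would show, and whether chlorine or methoxy on the phenyl group would follow the same order as fluorine. Among the compounds shown here, they also leave open how a benzyl group or a pyridine ring on that nitrogen would compare, since only one saturated ring and two difluorophenyl groups stand there.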